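Fluoro on the arylsulfanyl ring of a kinase scaffold

This account rests on a few compounds, and the source may have more. Where it says the series, first, only, none or still open, it means among the compounds named here.

Of the compounds shown here, three have been measured in an assay on isolated protein for inhibition of RAC-alpha serine/threonine-protein kinase (Homo sapiens), tested at 30 uM; on this read-out higher numbers stand for more inhibition at the one concentration tested (going by the name of the read-out) and lower numbers for less inhibition. Compound 1 `c1ccc(-[n+]2c[nH]c3ncncc32)cc1` gives 0%, and compound 2 `Fc1ccc(-[n+]2c[nH]c3ncncc32)cc1` gives 0%. Compound 3 `Cn1c(-c2ccc([S+](C)[O-])cc2)nc2c(Sc3ccccc3)ncnc21` gives 4%. The difference between the core of compound 3 and the core of compound 1 is not broken down here.

Compound 2 differs from compound 1 by fluoro in place of hydrogen on an aromatic carbon. This change produced no change at the digits printed from compound 1 to compound 2 (within the scatter).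

Compound 4 `Cn1c(-c2ccc([S+](C)[O-])cc2)nc2c(Sc3ccc(F)cc3)ncnc21` has not been measured. It differs from compound 3 by fluoro in place of hydrogen on an aromatic carbon. This is the same kind of change as that from compound 1 to compound 2, though the place differs: in compound 4 the fluoro sits para to a large group, whereas in compound 2 it sits para to a group of 9 heavy atoms.

The step from compound 3 to compound 4 is expected to be no change at the digits printed from compound 3 to compound 4 (within the scatter), because the earlier step of no change at the digits printed from compound 1 to compound 2 (within the scatter) was flat. Compound 4 is therefore estimated to give 4%, with the range 0% to 15% in this assay.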

Compound 4, a percentage reported as inhibition, at one concentration (the size of the read-out at that concentration, not a potency): 10%
For compound 4 the middle estimate is 6 percentage points below the measured one; low and high end bracket the measured number.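

In this assay, fluoro in place of hydrogen on the phenylsulfanyl group gave a number 6 percentage points higher from compound 3 to compound 4 (within the scatter). Set beside the earlier step, the same change reads alike on the two cores: the same change on two cores in this assay, no change at the digits printed (within the scatter) from compound 1 to compound 2 and a number 6 percentage points higher (within the scatter) from compound 3 to compound 4, 6 percentage points apart, within the scatter of two such steps

Among the compounds shown here, neither step lies beyond the scatter, so the comparison shows only that the change stayed within the scatter on both cores. It does not show that fluoro would act alike on a core where the read-out moves clearly, nor does it show that the change has any effect of its own on either core.

The compounds shown leave open whether another group on the same aromatic carbon, such as an amine, a carboxylic acid or a longer chain, would move the read-out beyond the scatter. They also leave open the potency of all these compounds, since each is described by a reading at a single concentration.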